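The compounds below may be only part of what the source reports. "The series", "measured", "known", "first", "only" and "open" are said of these compounds alone.

The study concerns four closely related compounds, three of them already measured. Compound 1 `CC1=C(CC[C@@H]2[C@@]3(C)CC[C@@H](O)C(C)(C)O[C@@H]3CC[C@]2(C)O)[C@](C)(C/C=C/C(C)(C)O)[C@H](O)CC1` was tested in a functional assay on KB-C2 cells (Homo sapiens) for cytotoxicity, read by MTT assay, with a stated time of 68 h; a lower number here means a stronger inhibitor, a higher number a weaker inhibitor; for compound 1 the read-out is a limit of the assay rather than a number, > 50000 nM. Compound 2 `CC1(C)O[C@@H]2CC[C@](C)(O)[C@H](CCC3C(C=O)=CCC4C(CC[C@@]4(C)O)C3(C)C)[C@@]2(C)CCC1=O` was tested in the same way, and in this assay compound 2 also returns only a limit, > 50000 nM. Compound 3 `CC1(C)C(CC[C@@H]2[C@@]3(C)CC[C@@H](O)C(C)(C)O[C@@H]3CC[C@]2(C)O)C(CO)=CCC2C1CC[C@@]2(C)O` completes the measured set, and in this assay compound 3 likewise gives a limit, > 50000 nM. The picture is therefore uniform: the limit of > 50000 nM in this assay, at which 3 of the 3 values shown sit. Among the measured compounds shown here, compound 2 stands exactly where the other two stand, and no step between any pair of measured compounds can be sized, since none of them yields a number.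

Compound 4 `CC1(C)O[C@@H]2CC[C@](C)(O)[C@H](CCC3C(CO)=CCC4C(CC[C@@]4(C)O)C3(C)C)[C@@]2(C)CCC1=O` has not yet been measured. It differs from compound 2 in a single place: hydroxymethyl in place of formyl on a double-bonded ring carbon. Compound 3 already carries a hydroxymethyl group and sits at the limit, > 50000 nM. For the measured compounds named here, with no measured step available, the expected step that the limit leaves unreadable from compound 2 to compound 4 is none beyond the scatter. Compound 4 is accordingly expected to remain at the limit, estimated at 100000 nM, with a range from 50000 nM to 300000 nM.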

Compound 4, half-maximal inhibitory concentration: > 50000 nM
Compound 4: no number, only a limit (the forecaster's own chance of this, stated with the estimate: 85%); the middle value does not contradict the limit.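

No step can be read between compound 2 and compound 4, the exchange of formyl for hydroxymethyl, since both compounds give only a limit in this assay and the set stays uniform: the limit of > 50000 nM in this assay, at which 4 of the 4 values shown sit.

The compounds shown leave open how strong any of them is in this assay and whether formyl or hydroxymethyl at this place makes any difference there.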